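Replacing an Aryl Ether with Isobutyl on the Quinoline-Type Core

The source may report more compounds than this note shows. Statements on the series, on what has been measured and on what is new or still open speak of the compounds shown alone.

Compound 2 `COc1ccc(Oc2ccc3c(NCCCNCc4cc(F)ccc4OC)ccnc3c2)cc1` gives 14500 nM in a physicochemical assay for solubility, with a stated time of 18 h, at pH 7.4 (a lower number here means a less soluble compound, a higher number a more soluble compound), and compound 3 `COc1ccc(Oc2ccc3c(NCCCNCc4cccc(OC)c4O)ccnc3c2)cc1` gives 14500 nM, so that no change at the digits printed from compound 2 to compound 3 (within the scatter); the two stand together at the low end of three numbers. Compound 1 `COc1ccc(-c2ccc3c(NCCCNCc4cccc(OC)c4O)ccnc3c2)cc1` gives 32000 nM, and a 2.2-fold lower number from compound 1 to compound 3 (0.34 log units; beyond the scatter). Compound 4 `COc1ccc(F)cc1CNCCCNc1ccnc2cc(CC(C)C)ccc12` differs from compound 2 in that (isobutyl in place of 4-methoxyphenoxy on an aromatic carbon). For the measured compounds named here, the only measured step at that aromatic carbon is the modest one from compound 1 to compound 3, and no measured pair exchanges a ring for a chain there, so the size of the step is uncertain. A modest step, a 1.2-fold lower number from compound 2 to compound 4 (0.08 log units; within the scatter), is expected, and compound 4 is estimated at 12000 nM, within 4000 nM to 36000 nM.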

Compound 4, solubility: 4200 nM
For compound 4 the middle estimate is 2.9-fold (0.46 log units) above the measured one, within the range that was stated.
By their numbers in this assay, from the lowest: compound 4; then compounds 2 and 3 (each within the scatter of the next); then compound 1.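

Taking out 4-methoxyphenoxy for isobutyl on this aromatic carbon gives a 3.5-fold lower number from compound 2 to compound 4 (0.54 log units; beyond the scatter) in this assay and is the first change at this carbon to remove the ring from the group there. The earlier step at this carbon, a 2.2-fold lower number from compound 1 to compound 3 (0.34 log units; beyond the scatter) and also beyond the scatter, kept an aromatic ring in the group. Nothing measured here accounts for the new step.

Still open, going by these compounds, is whether a chain carrying an amine or a carboxylic acid would behave like isobutyl at this carbon. Also open, on these data alone, is whether the step holds with 2-hydroxy-3-methoxyphenyl in place of 5-fluoro-2-methoxyphenyl.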